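The compounds below may be only part of what the source reports. "The series", "measured", "known", "first", "only" and "open" are said of these compounds alone.

Compound 1 `Nc1ncnc2c1ncn2[C@@H]1O[C@H](CNC(=O)C[C@H](N)C(=O)O)[C@@H](O)[C@H]1O` and compound 2 `CN(CC[C@H](N)C(=O)O)C[C@H]1O[C@@H](n2cnc3c(N)ncnc32)[C@H](O)[C@@H]1O` share the adenosine-derived core, and compound 2 carries the amino-acid bearing chain on a methylated amine nitrogen. Going by the values given here, in an assay for inhibition of tRNA (cytosine(38)-C(5))-methyltransferase (Homo sapiens), with a stated time of 5 min, tested at 100 uM (a lower number here means less inhibition, a higher number more inhibition at the concentration tested (going by the name of the read-out)), compound 1 gives no result reported; compound 2 is the only one of the pair with a number, and in this assay compound 2 gives 30.3%, which places it as the sole reference point for the step that follows.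

Compound 3 `Nc1ncnc2c1ncn2[C@@H]1O[C@H](CN(CC[C@H](N)C(=O)O)CC2CC2)[C@@H](O)[C@H]1O` is the next compound. It differs from compound 2 in one place: cyclopropyl in place of hydrogen on a saturated chain carbon bound to an amine nitrogen. Viewed one bond further out, the change reads methyl to cyclopropylmethyl on the amine nitrogen.

Among the compounds with values here, no measured pair in this set shows the effect of such a change, so the expectation rests on compound 2 alone. The step from the methylated amine of compound 2 to the cyclopropylmethyl amine of compound 3 is expected to be modest and upward, a number 9.7 percentage points higher from compound 2 to compound 3 (within the scatter) in this assay, though a step no larger than the usual scatter cannot be ruled out. On that basis compound 3 is estimated to give 40% in this assay, with a plausible range from 15% to 65%.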

Compound 3, a percentage reported as inhibition, at one concentration (the size of the read-out at that concentration, not a potency): 27.5%
The estimate for compound 3 lay 12.5 percentage points above the measured number; measured number inside the range.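

Going by these compounds alone, the step gives the first reading of this position: putting cyclopropyl in place of hydrogen on a saturated chain carbon bound to an amine nitrogen, which turns methyl into cyclopropylmethyl, yields a number 2.8 percentage points lower from compound 2 to compound 3 (within the scatter) in this assay. Within this read-out, the added three-membered ring of carbon therefore leaves compound 3 indistinguishable from compound 2, so a substituent of 3 further heavy atoms at this place is compatible with inhibition of the same measured size. The data shown offer no explanation for this result, and no independent measurement bears on it.

As far as these compounds go, both numbers describe inhibition at one concentration and are not potencies, so any difference in potency between compound 2 and compound 3 remains open. With only this one readable step, the compounds shown also leave open how this assay would respond if a longer chain, a phenyl ring, or a carboxylic acid stood on the amine nitrogen in place of methyl or cyclopropylmethyl.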